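The source may report more compounds than this note shows. Statements on the series, on what has been measured and on what is new or still open speak of the compounds shown alone.

Measured so far:
compound 1, `CCN(Cc1c(C(F)(F)F)nc2n(-c3c(C)cc(C)cc3C)c(Cl)cn12)CC1CC1`, 9 nM
compound 2, `Cc1cc(C)c(-n2c(Cl)cn3c(CN4CCCC4Cc4ccccc4)c(C(F)(F)F)nc23)c(C)c1`, 190 nM

In an assay on cells for displacement of a labelled ligand from corticotropin-releasing factor receptor 1 (Homo sapiens), with a stated time of 100 min (a lower number here means a stronger inhibitor, a higher number a weaker inhibitor), compound 1 gives 9 nM, the lowest of the two numbers measured; the nearest is compound 2, whose value of 190 nM lies beyond the usual scatter of this assay. Compound 2 carries a cyclic amine on the saturated chain carbon bound to an aromatic carbon of the shared core, where compound 1 carries an open amine.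

Compound 3, `Cc1cc(C)c(-n2c(Cl)cn3c(CN4CCC(c5ccccc5)C4)c(C(F)(F)F)nc23)c(C)c1`, has not yet been measured in this assay. It differs from compound 1 in one place: 3-phenylpyrrolidin-1-yl in place of (cyclopropylmethyl)(ethyl)amino on a saturated chain carbon bound to an aromatic carbon. Like compound 2, it replaces the open amine of compound 1 with a cyclic amine bearing a benzene ring, so its number is expected to move upward, in the direction of weaker inhibition, since compound 2 gives 190 nM in this assay. The step from compound 1 to compound 3 is estimated at a 6.7-fold higher number from compound 1 to compound 3 (0.82 log units; beyond the scatter), beyond the scatter. Compound 3 is therefore expected to give about 60 nM in this assay, within a range of 15 nM to 250 nM.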

Compound 3, inhibition constant: 610 nM
The estimate for compound 3 lay 10-fold (1.01 log units) below the measured number; measured number outside the range, above it.
By their numbers in this assay, from the lowest: compound 1; then compound 2; then compound 3.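

In this assay, going by these compounds alone, exchanging the open (cyclopropylmethyl)(ethyl)amino group for 3-phenylpyrrolidin-1-yl on a saturated chain carbon bound to an aromatic carbon gives a 68-fold higher number from compound 1 to compound 3 (1.83 log units; beyond the scatter), and this is the first step at this position that isolates a single change. With the rest of the structure held constant, it shows that the choice of amine here can by itself move the number by a large margin, so this position is far from indifferent to what it carries. Nothing measured here bears on why the number rises, so the step cannot be divided among closing the ring, adding the benzene ring and enlarging the group.

The compounds shown leave open whether a plain pyrrolidine without the benzene ring, or a morpholine, would stay close to compound 1 at 9 nM. They also leave open whether an open amine with longer chains, such as dipropylamino, would be tolerated as well as the (cyclopropylmethyl)(ethyl)amino group.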